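Dimethoxyphenyl in place of fluorophenyl on the shared core

The source may report more compounds than this note shows. Statements on the series, on what has been measured and on what is new or still open speak of the compounds shown alone.

Compound 1 `COc1ccc(-c2cc(C(=O)Nc3nc4ccc(F)cc4s3)nc3cc(-c4ccccc4)nn23)cc1OC`: in a functional assay on MCF7 cells (Homo sapiens) for cytotoxicity, read by MTT assay, with a stated time of 48 h (on this read-out higher numbers stand for weaker inhibition and lower numbers for stronger inhibition), compound 1 gives 22400 nM.
Compound 2 `Cc1cc2nc(NC(=O)c3cc(-c4ccc(F)cc4)n4nc(-c5ccccc5)cc4n3)sc2cc1C`: in this assay compound 2 gives 17000 nM.

Compound 2 holds the lower of the two numbers, yet compound 1 sits within the scatter of it, so no order between them is claimed. Compound 3 `COc1ccc(-c2cc(C(=O)Nc3nc4cc(C)c(C)cc4s3)nc3cc(-c4ccccc4)nn23)cc1OC` differs from compound 2 in one place: 3,4-dimethoxyphenyl in place of 4-fluorophenyl on an aromatic carbon. Compound 1 already carries the same 3,4-dimethoxyphenyl on the shared core, and its number does not separate from that of compound 2, so no step beyond the scatter is expected in this assay. The step from compound 2 to compound 3 is expected to be a 1.2-fold higher number from compound 2 to compound 3 (0.07 log units; within the scatter). Compound 3 is estimated at 20000 nM, with a range from 8000 nM to 50000 nM.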

Compound 3, half-maximal inhibitory concentration: 2510 nM
Compound 3: middle estimate off by 8.0-fold (0.90 log units), on the high side; the measured number lies below the stated range.
By their numbers in this assay, from the lowest: compound 3; then compounds 2 and 1 (each within the scatter of the next).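

In this assay this position proves sensitive: with 5,6-dimethyl-1,3-benzothiazol-2-yl held on the amide-type nitrogen, 3,4-dimethoxyphenyl in place of 4-fluorophenyl brings a 6.8-fold lower number from compound 2 to compound 3 (0.83 log units; beyond the scatter). The amide-type nitrogen responds as well: with 3,4-dimethoxyphenyl held, 5,6-dimethyl-1,3-benzothiazol-2-yl in place of 6-fluoro-1,3-benzothiazol-2-yl brings an 8.9-fold lower number from compound 1 to compound 3 (0.95 log units; beyond the scatter). No measurement at hand explains either step. As far as these compounds go, whether a single methoxy group on the phenyl ring would suffice remains open, as does how an amine there would read. The compounds also leave open whether the step at this position holds with 6-fluoro-1,3-benzothiazol-2-yl on the amide-type nitrogen.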